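This account rests on a few compounds, and the source may have more. Where it says the series, first, only, none or still open, it means among the compounds named here.

Compound 1, with the structure `COC(=O)/C(=C/c1ccccc1)CN1C(=O)[C@@H](OC)[C@H]1c1cccc(C(F)(F)F)c1`, carries a 3-(trifluoromethyl)phenyl group on its shared core, and in a functional assay on MCF7 cells (Homo sapiens) for antiproliferative activity, read by MTT assay, with a stated time of 48 h (a lower number here means a stronger inhibitor, a higher number a weaker inhibitor), compound 1 stands at no result reported, so no single number for it is available. The only measured relative in the set is compound 2, `CCOC(=O)/C(=C/c1ccccc1)CN1C(=O)[C@@H](OC)[C@H]1c1ccccc1Br`, which in this assay gives 5790 nM; it differs from compound 1 in more than one place, so its value is only a rough guide to where this series sits. Compound 3, `COC(=O)/C(=C/c1ccccc1)CN1C(=O)[C@@H](OC)[C@H]1c1ccc(F)cc1`, is the unmeasured partner of compound 1. The change between them is 4-fluorophenyl in place of 3-(trifluoromethyl)phenyl on a saturated ring carbon. Going by the values given here, with no measured pair of this kind to lean on, the expectation is that the step from compound 1 to compound 3 in this assay stays modest, in no firm direction, and may not exceed the usual scatter. On that basis compound 3 is expected to reach about 5000 nM in this assay, most likely within 1500 nM to 20000 nM.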

Compound 3, half-maximal inhibitory concentration: 15600 nM
For compound 3 the middle estimate is 3.1-fold (0.49 log units) below the measured one; measured number inside the range.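

In this assay, going by these compounds alone, compound 1 has no single number, so no step from it to compound 3 can be read. From the compounds shown here alone, what replacing 3-(trifluoromethyl)phenyl with 4-fluorophenyl does to the activity stays open. Nothing shown here offers an explanation for the value of compound 3.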